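The source may hold more compounds than are shown below. What is called first, only, known or untested is meant among the compounds shown, and "the series" means these compounds.

Three compounds of the series have so far been run in a functional assay on FM3A cells (Mus musculus); a lower number here means a stronger inhibitor, a higher number a weaker inhibitor. Compound 1 `CC1=CC(=N)C(c2ccccc2)(c2ccccc2)O1` gives 25.4 ug/mL in this assay; compound 2 `C/C(=C\COc1ccc2ccc(=O)oc2c1)C1=CC(=N)C2(CCCCC2)O1` gives 15.8 ug/mL; compound 3 `O=C1C=C(c2ccccc2)OC1` gives 31.4 ug/mL. On these numbers compound 3 carries the highest value of the three, but its gap to compound 1 and its gap to compound 2 both fall within the usual scatter of repeated measurements, so no order among the three can be read from them and none can be called more or less potent than another.

Compound 4 `COc1ccccc1C1=CC(=O)CO1` is not yet measured. It shares the core of compound 3 and differs from it by methoxy in place of hydrogen on an aromatic carbon. No change of this kind between two measured compounds is available in the series, so the size of the step cannot be taken from the numbers. The expectation, resting only on the closeness of the three measured values, is a step of no more than the scatter and no preferred direction: the step estimated here is a 1.1-fold lower number from compound 3 to compound 4 (0.05 log units; within the scatter). Compound 4 is accordingly estimated at 28 ug/mL in this assay, with an expected range between 12 ug/mL and 65 ug/mL.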

Compound 4, concentration for 50% inhibition: > 100 ug/mL
Compound 4 ended at the assay's limit (the forecaster's own chance of this, stated with the estimate: 10%); middle value at least 3.5-fold (0.55 log units) away from the limit.
By their numbers in this assay, from the lowest: compounds 2, 1 and 3 (each within the scatter of the next). At a limit, above all of these: compound 4.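

For the compounds shown here, the step of an at least 3.1-fold higher number from compound 3 to compound 4 (0.50 log units; beyond the scatter) is the only one so far, and it shows that in this assay methoxy in place of hydrogen at this place, ortho to a group of 6 heavy atoms, is not a neutral change on this core. On these data alone, compound 4 gives > 100 ug/mL, which is a limit of the assay and not a number, so the step fixes only the smallest size the change can have and its full size remains unknown. This is also the first value in the series that can be separated from another beyond the scatter, and it stands alone at the limit: the limit of > 100 ug/mL in this assay, at which 1 of the 4 values shown sits.

Open is whether the step belongs to methoxy in particular or would also follow from a hydroxyl, a fluorine atom or an amine on the same aromatic carbon, none of which is among the compounds shown. Also open, as far as these compounds go, is whether methoxy on an aromatic carbon of compound 1, with its different core, would give a step of similar size, and whether a longer chain such as ethoxy would go further or less far.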